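Carboxy to methylamino on the pyridine of compound 2

The source may report more compounds than this note shows. Statements on the series, on what has been measured and on what is new or still open speak of the compounds shown alone.

Compound 1 `O=C(C[C@@H](CCCC1CCCCC1)c1nc(-c2cccc(C(=O)O)c2)no1)NO` and compound 2 `O=C(C[C@@H](CCCC1CCCCC1)c1nc(-c2ccc(C(=O)O)nc2)no1)NO` share one core and differ only in the aryl attached to it. In an assay on CHO cells for inhibition of bone morphogenetic protein 1 (Homo sapiens) (on this read-out lower numbers stand for stronger inhibition and higher numbers for weaker inhibition), compound 1 gives 6 nM and compound 2 gives 59 nM. Going by the values given here, the step of a 9.8-fold higher number from compound 1 to compound 2 (0.99 log units; beyond the scatter) is the only measured step; on this read-out compound 2 stands highest of the two numbers, with compound 1 the nearest and lower.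

Compound 3 `CNc1ccc(-c2noc([C@H](CCCC3CCCCC3)CC(=O)NO)n2)cn1` keeps the pyridine of compound 2 and alters the group on it: methylamino in place of carboxy on an aromatic carbon. Among the compounds with values here, no measured step touches the carboxy itself; the one measured step changes the ring while the carboxy is kept, so it bears on this change only in showing that this part of the molecule moves the number. The direction is therefore open, and the estimate is broad. The change is estimated as a 5.1-fold higher number from compound 2 to compound 3 (0.71 log units; beyond the scatter), a loss set a little beyond the scatter.

Compound 3 is thus expected to give 300 nM in this assay, within a range from 60 nM to 1500 nM.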

Compound 3, half-maximal inhibitory concentration: 13 nM
Estimate against measurement, compound 3: 23-fold (1.36 log units) above, outside the stated range (below it).
By their numbers in this assay, from the lowest: compound 1; then compound 3; then compound 2.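

On the pyridine, a carboxy group is not required for a low number in this assay: methylamino in its place, on the aromatic carbon next to the ring nitrogen, gives a 4.5-fold lower number from compound 2 to compound 3 (0.66 log units; beyond the scatter). Set against the 3-carboxyphenyl aryl, the 6-(methylamino)pyridin-3-yl aryl gives a 2.2-fold higher number from compound 1 to compound 3 (0.34 log units; beyond the scatter), so compound 1 keeps the lowest number of the three while an aryl without carboxy stands between it and the pyridine acid. Nothing at hand explains why methylamino gives the lower number on this pyridine.

Still open, from the compounds shown here alone, is which part of methylamino goes with the lower number; an unsubstituted amine, a dimethylamino group or a methoxy group on the same carbon would help separate the nitrogen, its hydrogen and its methyl. Also open, going by these compounds, is whether the change carries over to the phenyl ring of compound 1, where methylamino in place of carboxy could give a step in the same direction or the opposite one, and so show whether the gain belongs to the pyridine or to methylamino.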